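The source may report more compounds than this note shows. Statements on the series, on what has been measured and on what is new or still open speak of the compounds shown alone.

Working notes on the series in a functional assay on NUGC-3 cells (Homo sapiens) for antiproliferative activity, read by sulforhodamine B assay; a lower number here means a stronger inhibitor of growth, a higher number a weaker inhibitor of growth. Compound 3 `COc1ccc(C(=O)Nc2nc3c(OC)cccc3s2)cc1` gives 3.46 ug/mL. For the measured compounds named here, this is the highest of the two numbers measured so far; the nearest is compound 2 `Cc1cc(C)c2sc(NC(=O)c3ccc(C#N)cc3)nc2c1`, which gives 0.62 ug/mL. Compound 1 `COc1cccc2sc(NC(=O)c3ccc(C(F)(F)F)cc3)nc12` reaches only the limit of > 10 ug/mL in this assay, a limit and not a number, which corresponds to the limit of > 10 ug/mL in this assay, at which 1 of the 3 values shown sits.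

The step under consideration runs from compound 3 to compound 4 `COc1cccc2sc(NC(=O)c3ccc(C#N)cc3)nc12`, which carries cyano in place of methoxy on an aromatic carbon. Going by the values given here, one measured step touches the same position: an at least 2.8-fold lower number from compound 1 to compound 3 (0.46 log units; beyond the scatter). That step exchanged trifluoromethyl for methoxy, not methoxy for cyano, and it starts from a limit, so it bounds rather than fixes the size of what a change at this position can do. Among the compounds with values here, compound 2 carries the cyano group on a different core, and its value stands well below that of compound 3; no step between them is computed, and the two values show only that a cyano-bearing member of the series can sit at the lower end.

The expected step is a 2.3-fold lower number from compound 3 to compound 4 (0.36 log units; beyond the scatter), a modest one toward a lower number. The estimate for compound 4 in this assay is 1.5 ug/mL, with a range from 0.5 ug/mL to 5 ug/mL.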

Compound 4, concentration for 50% growth inhibition: > 10 ug/mL
Compound 4: only a limit was reported; the forecaster's own chance of this, stated with the estimate: 10%; at least 6.6-fold (0.82 log units) between middle value and limit.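

In this assay, cyano in place of methoxy, para to a large group, gives an at least 2.8-fold higher number from compound 3 to compound 4 (0.46 log units; beyond the scatter), so the earlier rise in growth inhibition on going to methoxy at this position is not a general feature of replacing trifluoromethyl. For the compounds shown here, on the shared core of compounds 1, 3 and 4, methoxy is now the only one of the three groups at this position with a measured number, and both trifluoromethyl and cyano stop at the assay's limit, so this pattern rests on three compounds alone and the step between compound 1 and compound 4 cannot be read. The low value of compound 2 does not transfer to this core, since compound 2 differs from compound 4 in more than one place, and the upper end of the assay is now reached twice: the limit of > 10 ug/mL in this assay, at which 2 of the 4 values shown sit.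

Going by these compounds, how far compound 1 and compound 4 lie beyond the limit remains unknown, so their order stays open. Also open, on these data alone, is whether the number seen with methoxy persists with an ethoxy group, a hydroxyl or a dimethylamino group at this position, or with methoxy on the core of compound 2.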